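A few compounds are considered here, and "the series" means these few. Any claim that something is new, unique, unknown or untested is made for them only; others in the source may bear on it.

Measured in a functional assay on MCF7 cells (Homo sapiens) for cytotoxicity, read by WST assay, with a stated time of 72 h; a higher number here means a weaker inhibitor, a lower number a stronger inhibitor:
Compound 1 `O=C1Nc2c(ccc(F)c2F)C1(c1ccc(O)cc1)c1ccc(F)cc1`: 2.6 nM
Compound 2 `CCCC1(c2ccc(O)cc2)C(=O)Nc2c1ccc(F)c2F`: > 1000 nM

Compound 2 sits at the limit of > 1000 nM in this assay, at which 1 of the 2 values shown sits, so its value is a limit and not a number.

Compound 3 `O=C1Nc2c(ccc(F)c2F)C1(c1ccc(O)cc1)C1CCCC1` has cyclopentyl in place of propyl on a saturated ring carbon.

Within the data shown here, only one measured step bears on this carbon, and it is large: an at least 380-fold higher number from compound 1 to compound 2 (2.58 log units; beyond the scatter). Given that step, putting a ring back at this carbon, as in compound 1, is expected to lower the number in this assay, though probably not as far as the value of compound 1.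

The expected change is an at least 6.6-fold lower number from compound 2 to compound 3 (0.82 log units; beyond the scatter).

For compound 3 the estimated value is 150 nM, with an expected range of 15 nM to 1500 nM.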

Compound 3, half-maximal inhibitory concentration: 12 nM
Compound 3: the middle estimate sits 13-fold (1.10 log units) above what was measured; the whole stated range lies above it.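

Swapping propyl for cyclopentyl at this carbon brings back strong activity, giving an at least 83-fold lower number from compound 2 to compound 3 (1.92 log units; beyond the scatter). An aromatic ring is therefore not essential here, although replacing 4-fluorophenyl with cyclopentyl still costs some activity, giving a 4.6-fold higher number from compound 1 to compound 3 (0.66 log units; beyond the scatter). The gain over propyl is only a minimum, as compound 2 has a limit and not a number: the limit of > 1000 nM in this assay, at which 1 of the 3 values shown sits.

As far as these compounds go, whether a ring is what counts, or simply more carbon, stays open, and a longer chain such as pentyl would help separate the two. Also open, from the compounds shown here alone, is how a ring carrying an amine, such as piperidine, would fare at this carbon.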